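The source may report more compounds than this note shows. Statements on the series, on what has been measured and on what is new or still open speak of the compounds shown alone.

Measured compounds:
compound 1 `C=C1C(=O)[C@]23C[C@@]1(O)CC[C@H]2c1ccc(O)c(C)c1[C@@H]3Cn1cc(-c2ccccc2)nn1`: 1740 nM
compound 2 `C=C1C[C@]23C[C@@]1(O)CC[C@H]2c1ccc(OS(=O)(=O)c2ccc(C)cc2)c(C)c1[C@@H]3Cn1cc(-c2ccc(F)cc2)nn1`: > 20000 nM

For the measured compounds named here, in a functional assay on MCF7 cells (Homo sapiens) for cytotoxicity, read by MTT assay, with a stated time of 4 days (a higher number here means a weaker inhibitor, a lower number a stronger inhibitor), compound 1 gives 1740 nM and is the only compound with a number. Compound 2 gives > 20000 nM, a limit of the assay rather than a number. That is the limit of > 20000 nM in this assay, at which 1 of the 2 values shown sits. Compound 3 `C=C1C(=O)[C@]23C[C@@]1(O)CC[C@H]2c1ccc(O)c(C)c1[C@@H]3Cn1cc(-c2ccc(C)cc2)nn1` is not yet measured; it differs from compound 1 by methyl in place of hydrogen on an aromatic carbon. Going by the values given here, no step between measured compounds bears on this change, so the data set no direction. The change is expected to give a step of a 1.2-fold lower number from compound 1 to compound 3 (0.06 log units; within the scatter), within the scatter of this assay. Compound 3 is expected to give 1500 nM, between 600 nM and 4500 nM.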

Compound 3, half-maximal inhibitory concentration: 370 nM
The estimate for compound 3 lay 4.1-fold (0.61 log units) above the measured number, outside the stated range (below it).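

For the compounds shown here, the change from phenyl to 4-methylphenyl gives a 4.7-fold lower number from compound 1 to compound 3 (0.67 log units; beyond the scatter) in this assay and is the first step that can be read. This aromatic carbon, para to a large group, therefore responds to substitution, and a single methyl is enough to move the number beyond the scatter. No measured property shown here accounts for the step.

On these data alone, whether this response is particular to methyl remains open. A methoxy group, a chlorine or an amine on the same carbon would show how far it extends.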